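The source may report more compounds than this note shows. Statements on the series, on what has been measured and on what is new or still open speak of the compounds shown alone.

Compound 1 `COc1ncnc2c1c(I)cn2[C@@H]1O[C@H](CO)[C@@H](O)[C@H]1O` and compound 2 `CN(C)c1ncnc2c1c(-c1cc3ccccc3o1)cn2[C@@H]1O[C@H](CO)[C@@H](O)[C@H]1O` are the two compounds with measurements. In a functional assay on CCRF-CEM cells (Homo sapiens), read by MTT assay, with a stated time of 72 h (on this read-out higher numbers stand for weaker inhibition and lower numbers for stronger inhibition), compound 1 gives 1150 nM. For compound 2 the assay reports only a limit, > 20000 nM. Compound 2 therefore stands at the limit of > 20000 nM in this assay, at which 1 of the 2 values shown sits, and nothing more than that limit is known of it. Compound 1 and compound 2 differ in more than one place, so no single step can be read between them. Compound 3 `COc1ncnc2c1c(-c1cc3ccccc3o1)cn2[C@@H]1O[C@H](CO)[C@@H](O)[C@H]1O` has not yet been measured. It differs from compound 2 by methoxy in place of dimethylamino on an aromatic carbon. Going by the values given here, no step between measured compounds isolates this change, so its size in this assay is not known from the data. The step from compound 2 to compound 3 is expected to be modest, estimated as an at least 2.0-fold lower number from compound 2 to compound 3 (0.30 log units; that floor lies within the scatter). Compound 3 is expected to give about 10000 nM, with a range from 2000 nM to 20000 nM.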

Compound 3, half-maximal inhibitory concentration: 5370 nM
Beside the measured number, compound 3's estimate is 1.9-fold (0.27 log units) above it, within the range that was stated.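

In this assay, methoxy in place of dimethylamino on the aromatic carbon next to the ring nitrogen, with 1-benzofuran-2-yl held constant, gives an at least 3.7-fold lower number from compound 2 to compound 3 (0.57 log units; beyond the scatter), so the group at this position changes the read-out beyond the scatter. That step is only a floor because compound 2 is known only as a limit: the limit of > 20000 nM in this assay, at which 1 of the 3 values shown sits. With methoxy held constant, 1-benzofuran-2-yl in place of iodo gives a 4.7-fold higher number from compound 1 to compound 3 (0.67 log units; beyond the scatter), which shows that this second exchange on the shared core also moves the number beyond the scatter, here towards weaker inhibition.

The compounds shown leave open how a primary amine or an ethoxy group would read in place of methoxy. They also leave open whether a phenyl or a thiophene ring in place of 1-benzofuran-2-yl would stay closer to iodo.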